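Chloro for hydrogen on the fused core of compound 3

This account rests on a few compounds, and the source may have more. Where it says the series, first, only, none or still open, it means among the compounds named here.

Compound 1 `O=C(NCc1cccc(Cl)c1)c1cc(Cl)c2cn(CCn3cccn3)nc2c1` gives 225 nM in an assay on isolated protein for inhibition of thyroid hormone receptor beta (Homo sapiens), read by fluorescence, with a stated time of 30 min; on this read-out higher numbers stand for weaker inhibition and lower numbers for stronger inhibition. Compound 2 `COc1cc(C(=O)NCc2cccc(Cl)c2)cc2nn(CCn3cccn3)cc12` differs from compound 1 only by a methoxy in place of a chloro on an aromatic carbon. In this assay compound 2 gives 464 nM. The step of a 2.1-fold higher number from compound 1 to compound 2 (0.31 log units; beyond the scatter) is modest but beyond the scatter. Compound 3 `CCCN(CC1CCOC1)C(=O)c1ccc2oc(NCc3cccc(Cl)c3)nc2c1` gives 214 nM in this assay. Compound 3 holds the lowest of the three numbers, but its gap to compound 1 lies within the scatter, so the two cannot be ordered; only compound 2 stands clearly higher.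

Compound 4 `CCCN(CC1CCOC1)C(=O)c1cc(Cl)c2oc(NCc3cccc(Cl)c3)nc2c1` has not yet been measured in this assay. It differs from compound 3 by chloro in place of hydrogen on an aromatic carbon, at a place on an aromatic carbon of a six-membered aromatic ring of carbon only, part of a fused system of two rings, ortho to a fused ring, meta to a fused ring and meta to a large group. Among the measured compounds shown here, no measured step exchanges chloro for hydrogen; the only step at hand, from compound 1 to compound 2, exchanges chloro for methoxy on a different core and bears on it only loosely. The step of a 1.2-fold lower number from compound 3 to compound 4 (0.08 log units; within the scatter) is therefore expected to stay within the scatter or be at most modest in the lower direction. Compound 4 is estimated at 180 nM, within 80 nM to 400 nM.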

Compound 4, half-maximal inhibitory concentration: 71 nM
Estimate against measurement, compound 4: 2.5-fold (0.40 log units) above, outside the stated range (below it).
By their numbers in this assay, from the lowest: compound 4; then compounds 3 and 1 (each within the scatter of the next); then compound 2.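

On this aromatic carbon, ortho to a fused ring, meta to a fused ring and meta to a large group, chloro in place of hydrogen gives a 3.0-fold lower number from compound 3 to compound 4 (0.48 log units; beyond the scatter) in this assay, so the position accepts chloro and the number responds to what sits there. This is the first direct comparison of chloro with hydrogen in the compounds shown: the earlier step exchanged chloro for methoxy on a different core, and it offered no hydrogen reference, so it could not show what the chloro itself contributes at any position. The data at hand offer no measurement that accounts for the size of this step.

The compounds shown leave open whether fluoro, bromo, methyl or an amine on this same aromatic carbon would give a number like that of compound 4 or one closer to that of compound 3, and so whether the step is particular to chloro. They also leave open whether chloro in place of hydrogen gives a step of similar size and direction on the core of compound 1, or with a different amide substituent on the core of compound 3.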